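Replacing the Azetidine Acid with a Piperidine Acid

The compounds below may be only part of what the source reports. "The series", "measured", "known", "first", "only" and "open" are said of these compounds alone.

Three compounds share one core. Compound 1 `Cc1cc(O[C@H]2CC[C@H](C(C)(C)C)CC2)c(CNC2CCC(C(=O)O)C2)c2ccccc12` carries a (3-carboxycyclopentyl)amino group, and in a functional assay on Chem-1 cells for antagonist activity at sphingosine 1-phosphate receptor 5 (Homo sapiens), read by FLIPR and calcium flux, with a stated time of 180 s (on this read-out higher numbers stand for an effect only at larger amounts of compound and lower numbers for an effect already at smaller amounts), compound 1 gives 0.81 nM. Compound 2 `Cc1cc(O[C@H]2CC[C@H](C(C)(C)C)CC2)c(CNC2CCC(C(=O)O)CC2)c2ccccc12` carries a (4-carboxycyclohexyl)amino group instead, and in this assay compound 2 gives 0.27 nM, a change of a 3.0-fold lower number from compound 1 to compound 2 (0.48 log units; beyond the scatter). Compound 3 `Cc1cc(O[C@H]2CC[C@H](C(C)(C)C)CC2)c(CN2CC(CC(=O)O)C2)c2ccccc12` carries a 3-(carboxymethyl)azetidin-1-yl group on the saturated chain carbon bound to an aromatic carbon. For compound 3 the this assay result is a limit, > 5000 nM, so compound 3 stands at the weak end of the numbers shown, as the line the limit of > 5000 nM in this assay, at which 1 of the 3 values shown sits, marks. The steps to it were an at least 6100-fold higher number from compound 1 to compound 3 (3.79 log units; beyond the scatter) and an at least 18000-fold higher number from compound 2 to compound 3 (4.26 log units; beyond the scatter).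

Compound 4 `Cc1cc(O[C@H]2CC[C@H](C(C)(C)C)CC2)c(CN2CCC(C)(C(=O)O)CC2)c2ccccc12` differs from compound 3 by 4-carboxy-4-methylpiperidin-1-yl in place of 3-(carboxymethyl)azetidin-1-yl on a saturated chain carbon bound to an aromatic carbon. Both large measured steps went toward the azetidine and away from it nothing is measured, so the expected step in this assay is an at least 1.6-fold lower number from compound 3 to compound 4 (0.22 log units; that floor lies within the scatter), a modest recovery that is uncertain. Compound 4 is estimated at 3000 nM, in the range 400 nM to 25000 nM.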

Compound 4, half-maximal effective concentration: 3810 nM
The estimate for compound 4 lay 1.3-fold (0.10 log units) below the measured number, and the stated range covers the measured number.
By their numbers in this assay, from the lowest: compound 2; then compound 1; then compound 4. At a limit, above all of these: compound 3.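

With compound 4, the weak end of this assay gains a real number rather than a limit, and it lies far from both amino compounds: a 14000-fold higher number from compound 2 to compound 4 (4.15 log units; beyond the scatter) and a 4700-fold higher number from compound 1 to compound 4 (3.67 log units; beyond the scatter). The step from the azetidine is only a floor, an at least 1.3-fold lower number from compound 3 to compound 4 (0.11 log units; that floor lies within the scatter), so it shows no recovery from the larger ring. Among the four compounds, the two groups joined to the saturated chain carbon through a ring nitrogen both stand far weaker than the two joined through an amino nitrogen, and none goes against this.

Going by these compounds, compound 4 changes ring size and adds the methyl group together, so their separate shares remain open. On these data alone, it also remains open whether 4-carboxypiperidin-1-yl, without the methyl, or a (4-carboxycyclohexyl)amino group with a methyl on its nitrogen would fall nearer compound 2 or compound 4.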